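Replacing hydroxy with dimethylamino on a growth inhibitor

This account rests on a few compounds, and the source may have more. Where it says the series, first, only, none or still open, it means among the compounds named here.

In a functional assay on SiHa cells (Homo sapiens) for inhibition, read by sulforhodamine B assay (a higher number here means a weaker inhibitor of growth, a lower number a stronger inhibitor of growth), compound 1 `Oc1cccc2[nH]c(-c3ccc(-c4ccc(-c5ccc(F)cc5)cc4)cc3)nc12` gives 9100 nM and compound 2 `Oc1ccc(-c2ccc(-c3ccc(-c4nc5c(O)cccc5[nH]4)cc3)cc2)cc1` gives 2410 nM, the lower of the two numbers and so the stronger result. Compound 3 `CN(C)c1ccc(-c2ccc(-c3ccc(-c4nc5c(O)cccc5[nH]4)cc3)cc2)cc1` keeps the rest of compound 2 but carries dimethylamino in place of hydroxy on an aromatic carbon, para to a large group (dimethylamino in place of hydroxy on an aromatic carbon). For the measured compounds named here, only one measured step bears on this position: fluoro gave way to hydroxy there (a 3.8-fold lower number from compound 1 to compound 2 (0.58 log units; beyond the scatter)), a modest change beyond the scatter. Compound 3 loses that hydroxy, though dimethylamino is not fluoro, and a single step is thin support. A modest rise in this assay is therefore expected (a 2.1-fold higher number from compound 2 to compound 3 (0.32 log units; beyond the scatter)), smaller than or similar to that one step. Compound 3 is estimated at 5000 nM (1800 nM to 14000 nM).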

Compound 3, concentration for 50% growth inhibition: 6240 nM
Compound 3: the middle estimate sits 1.2-fold (0.10 log units) below what was measured; the measured number falls inside the stated range.
By their numbers in this assay, from the lowest: compound 2; then compounds 3 and 1 (each within the scatter of the next).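

In this assay, swapping the 4-hydroxyphenyl end for 4-(dimethylamino)phenyl gives a 2.6-fold higher number from compound 2 to compound 3 (0.41 log units; beyond the scatter) and so moves away from compound 2 in the weaker direction, just as fluoro does in the earlier comparison. Of the three groups seen at this place, hydroxy therefore gives the lowest number, with its steps to both others beyond the scatter, while the two replacements cannot be told apart: the change gives a 1.5-fold lower number from compound 1 to compound 3 (0.16 log units; within the scatter) and stays within the scatter. No measurement here explains what sets hydroxy apart from the other two groups.

The compounds shown leave open whether this advantage belongs to hydroxy alone or is shared by related groups, such as methoxy or a simple unsubstituted amine. A carboxylic acid at the same place would also extend the comparison, and the step sizes here cannot predict its result.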